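What One Chloro May Do to Compound 2

The source may report more compounds than this note shows. Statements on the series, on what has been measured and on what is new or still open speak of the compounds shown alone.

In a functional assay on P388 cells (Mus musculus) for antiproliferative activity, read by colorimetric assay and MTT assay (a higher number here means a weaker inhibitor, a lower number a stronger inhibitor), compound 2 `O=[N+]([O-])c1ccc(S(=O)(=O)Nc2cccc3cc[nH]c23)cc1` gives 8.2 ug/mL and compound 1 `O=S(=O)(Nc1cc(Cl)cc2cc[nH]c12)c1ccc(Cl)cc1` gives 9.9 ug/mL, two numbers within the scatter of each other. Compound 3 `O=[N+]([O-])c1ccc(S(=O)(=O)Nc2cccc3cc(Cl)[nH]c23)cc1` gives 21 ug/mL.

Compound 4 `O=[N+]([O-])c1ccc(S(=O)(=O)Nc2cc(Cl)cc3cc[nH]c23)cc1` has not yet been measured. It differs from compound 2 by chloro in place of hydrogen on an aromatic carbon.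

Among the measured compounds shown here, one measured step bears on this change: a 2.6-fold higher number from compound 2 to compound 3 (0.41 log units; beyond the scatter). It is a modest step for the same kind of swap, but on a different carbon of the core, so it is only a rough guide. For the measured compounds named here, compound 1 also carries a chloro on the core, but no measured partner lacks only that chloro, so it offers no step of its own.

A small move toward a higher number, meaning a somewhat weaker inhibitor, is therefore expected, and it may not rise beyond the scatter. The expected change is a 1.3-fold higher number from compound 2 to compound 4 (0.13 log units; within the scatter). Compound 4 is estimated at 11 ug/mL, with an expected range from 5 ug/mL to 24 ug/mL.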

Compound 4, half-maximal inhibitory concentration: 13 ug/mL
Compound 4: the middle estimate sits 1.2-fold (0.07 log units) below what was measured, within the range that was stated.
By their numbers in this assay, from the lowest: compounds 2, 1, 4 and 3 (each within the scatter of the next, the first and the last beyond it).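

In this assay, chloro in place of hydrogen on the six-membered ring of the shared core gives a 1.6-fold higher number from compound 2 to compound 4 (0.20 log units; within the scatter), so this change cannot be told apart from no change, whereas the same swap on a different carbon gave a 2.6-fold higher number from compound 2 to compound 3 (0.41 log units; beyond the scatter). With that chloro on the core, nitro in place of chloro on the aromatic carbon of the other ring gives a 1.3-fold higher number from compound 1 to compound 4 (0.12 log units; within the scatter), so these two groups also cannot be told apart in this pair. No measurement available here explains either result.

As far as these compounds go, it remains open whether a larger or different group at this core position, such as an amine or a methoxy group, would also stay within the scatter of compound 2. A single pair for each swap also cannot show whether these small steps would hold on other members of the series.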